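Swapping a furan for a pyrazole on a thiazole acid core

The source may report more compounds than this note shows. Statements on the series, on what has been measured and on what is new or still open speak of the compounds shown alone.

Measured so far:
compound 1, `O=C(O)Cc1sc(C(c2ccccc2)c2ccccc2)nc1-c1ccccc1`, 80%
compound 2, `O=C(O)Cc1sc(C(c2ccc(F)cc2)c2ccc(F)cc2)nc1-c1ccco1`, 80%

Both compounds were tested in an in vitro functional assay on HEK285-7 cells for antagonist activity at prostaglandin D2 receptor 2 (Homo sapiens), read by BRET and beta-arrestin recruitment; a higher number here means a larger maximal response, a lower number a smaller maximal response. Compound 1 gives 80%, and compound 2 gives 80%. Among the measured compounds shown here, the two numbers are level at the digits printed, so compound 2 stands within the scatter of compound 1; nothing can be said about an order between them, and no step between measured compounds is available here. The shared core carries a carboxymethyl group and a large group, and the two measured compounds differ in more than one place, so their values show only that both reach a similar maximal response.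

Compound 3, `O=C(O)Cc1sc(C(c2ccc(F)cc2)c2ccc(F)cc2)nc1-c1cn[nH]c1`, has not yet been measured. It differs from compound 2 in one place: 1H-pyrazol-4-yl in place of furan-2-yl on an aromatic carbon. For the measured compounds named here, with no measured step to lean on, the expectation is that this change moves the maximal response in this assay little, if at all, beyond the scatter, perhaps slightly downward. For compound 3 the estimated value is 75%, with a range from 55% to 92%. This estimate means a step of a number 5 percentage points lower from compound 2 to compound 3 (within the scatter), which is expected to stay near the scatter.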

Compound 3, largest response reached (reported as efficacy), in percent of the reference or control that the assay uses: 80%
For compound 3 the middle estimate is 5 percentage points below the measured one; the measured number falls inside the stated range.
By their numbers in this assay, from the lowest: compounds 1, 2 and 3 (each within the scatter of the next).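

In this assay, putting 1H-pyrazol-4-yl in place of furan-2-yl on this aromatic carbon of the shared core gives no change at the digits printed from compound 2 to compound 3 (within the scatter). Among the compounds shown here, this is the first comparison here in which only one place differs, so, unlike the pair of compound 1 and compound 2, it can be tied to a single group: the ring next to the ring nitrogen and the ring atom bearing the carboxymethyl group. At this place, in this setting, a five-membered aromatic ring with 1 hetero atom, 0 hydrogen-bond donors and 1 hydrogen-bond acceptor can give way to one with 2 hetero atoms, 1 hydrogen-bond donor and 1 hydrogen-bond acceptor with no step beyond the scatter in the maximal response, and no measurement here offers an explanation for this.

The compounds shown leave open whether a group of a different kind on this carbon, such as an amine, a carboxylic acid or a longer alkyl chain, would give a step beyond the scatter. They also leave open whether the same swap would read alike with a large group other than the one carrying two 4-fluorophenyl rings.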